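The compounds below may be only part of what the source reports. "The series", "measured", "known", "first", "only" and "open" are said of these compounds alone.

Working notes on the spiro series.

Among the measured compounds shown here, compound 1 `CC(C)(C)c1ccc(C(=O)N2CCC3(CC2)C(=O)N(CC(=O)NCCC(=O)O)CN3c2ccccc2)cc1` is the weakest of the three compounds measured so far: in an assay on HEK293 cells for displacement of a labelled ligand from NPC1-like intracellular cholesterol transporter 1 (Homo sapiens) (a higher number here means a weaker inhibitor, a lower number a stronger inhibitor), compound 1 gives 11400 nM, the highest of the three numbers. Compound 2 `O=C(CN1CN(c2ccccc2)C2(CCN(C(=O)c3ccc(C4CCCCC4)cc3)CC2)C1=O)N1CCC(CO)CC1` gives 1100 nM in this assay, and compound 3 `CC(C)(C)OC(=O)N1CCN(C(=O)CN2CN(c3ccccc3)C3(CCN(C(=O)c4ccc(C5CCCCC5)cc4)CC3)C2=O)CC1` gives 3500 nM. For the measured compounds named here, both sit beyond the scatter below compound 1, but neither differs from compound 1 in a single place, so no single-point step among the measured compounds can be read off; all that the numbers show is that the two compounds carrying a cyclic amide at the glycine carbonyl score lower than compound 1 with its open-chain acid amide.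

Compound 4 `CC(C)(C)c1ccc(C(=O)N2CCC3(CC2)C(=O)N(CC(=O)N2CCCCC2CO)CN3c2ccccc2)cc1` is compound 1 with one change: 2-(hydroxymethyl)piperidin-1-yl in place of (2-carboxyethyl)amino on a carbonyl carbon. The leaving group carries the carboxylic acid; the entering group is a six-membered ring with a hydroxymethyl substituent, closer in kind to the amide portion of compound 2. On the basis of the values of compound 2 1100 nM and compound 3 3500 nM, both cyclic amides, a move downward from compound 1 beyond the scatter is expected, but with wide uncertainty because the two lower-scoring comparators differ elsewhere as well. The expected step from compound 1 to compound 4 is a 3.8-fold lower number from compound 1 to compound 4 (0.58 log units; beyond the scatter). For compound 4 the estimate is 3000 nM, with a range from 1200 nM to 8000 nM.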

Compound 4, half-maximal inhibitory concentration: 11800 nM
Compound 4: middle estimate off by 3.9-fold (0.59 log units), on the low side; the measured number lies above the stated range.
By their numbers in this assay, from the lowest: compound 2; then compound 3; then compounds 1 and 4 (each within the scatter of the next).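

On the core of compound 1, 2-(hydroxymethyl)piperidin-1-yl in place of (2-carboxyethyl)amino on a carbonyl carbon gives a 1.0-fold higher number from compound 1 to compound 4 (0.01 log units; within the scatter) in this assay, so this exchange, which removes the carboxylic acid and brings in a six-membered non-aromatic ring, leaves no measurable difference at this place. Among the compounds shown here, compound 4 also carries a cyclic amide at this carbonyl, so the link between that feature and a lower number, seen with only three compounds, no longer holds across the series: compound 4 goes against it, and a cyclic amide at this place is not enough on its own to separate a compound from compound 1. No measurement shown here bears on why the two groups read alike.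

Steps linking compound 2 or compound 3 to compound 1 or compound 4 cannot be read, so what sets those two compounds apart stays unassigned among their several differences. Also open, from the compounds shown here alone, is whether any group on this carbonyl carbon moves the number on the core of compound 1, for example a plain piperidin-1-yl without the hydroxymethyl, a morpholin-4-yl or a longer carboxylic acid chain.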